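Swapping the amide substituent in a kinase inhibitor series

The compounds below may be only part of what the source reports. "The series", "measured", "known", "first", "only" and "open" are said of these compounds alone.

Measured compounds:
- compound 1, `CNS(=O)(=O)c1ccccc1Nc1cc(-c2ccc3ccn(C)c3c2)c2nccnc2c1`: 104 nM
- compound 2, `CN1CCC(NS(=O)(=O)c2ccccc2Nc2cc(-c3ccc4ccn(C)c4c3)c3nccnc3c2)C1`: 33 nM
- compound 3, `CC(=O)N1CCC(NC(=O)c2ccncc2Nc2cc(-c3ccc4ccn(C)c4c3)c3nccnc3c2)CC1`: 18 nM

All three share a common core and were tested in an assay for inhibition of 6-phosphofructo-2-kinase/fructose-2,6-bisphosphatase 3 (Homo sapiens), read by ADP-Glo, with a stated time of 2 h; on this read-out higher numbers stand for weaker inhibition and lower numbers for stronger inhibition. Compound 3 gives the lowest number of the three. Its gap to compound 2 lies within the scatter, so the two cannot be ordered; compound 1 sits clearly higher than compound 3.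

Compound 4, `CC(=O)N1CCOC(CNC(=O)c2ccncc2Nc2cc(-c3ccc4ccn(C)c4c3)c3nccnc3c2)C1`, has not yet been measured. It differs from compound 3 by one change: (4-acetylmorpholin-2-yl)methyl in place of 1-acetylpiperidin-4-yl on an amide-type nitrogen.

Among the measured compounds shown here, no measured step covers this exact change. For the measured compounds named here, the only step available, a 3.2-fold lower number from compound 1 to compound 2 (0.50 log units; beyond the scatter), shows that enlarging a small nitrogen substituent on a related position shifted the number by a modest amount. That suggests changes at this part of the molecule tend to move the number only moderately, in either direction. For compound 4 the expectation is therefore a step of about a 1.4-fold higher number from compound 3 to compound 4 (0.14 log units; within the scatter), roughly neutral to slightly weaker. Compound 4 is estimated at 25 nM, within a range from 8 nM to 80 nM in this assay.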

Compound 4, half-maximal inhibitory concentration: 93 nM
Compound 4: middle estimate off by 3.7-fold (0.57 log units), on the low side; measured number above the stated range.
By their numbers in this assay, from the lowest: compounds 3 and 2 (each within the scatter of the next); then compounds 4 and 1 (each within the scatter of the next).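

In this assay, putting (4-acetylmorpholin-2-yl)methyl in place of 1-acetylpiperidin-4-yl on the amide-type nitrogen gives a 5.2-fold higher number from compound 3 to compound 4 (0.71 log units; beyond the scatter) and so weakens inhibition, showing that this position distinguishes between two acetylated six-membered rings of nearly the same heavy-atom count. The change has two parts, since the ring gains a second hetero atom and is also attached through an added methyl link. No measurement shown gives a reason for this step.

The compounds shown leave open which part carries the step, and a (1-acetylpiperidin-4-yl)methyl group on the same nitrogen would separate the two. Going by these compounds, the role of the acetyl group also remains open, and a piperidin-4-yl group with a free ring amine would test it.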